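Swapping the amide amine at the ester tail of compound 2

The source may hold more compounds than are shown below. What is called first, only, known or untested is meant among the compounds shown, and "the series" means these compounds.

Measured so far:
- compound 1, `CCOc1cc(NC(=O)C2(NC(=O)c3ccc4c(C5CCCC5)c(-c5ncc(Cl)cn5)n(C)c4c3)CCC2)ccc1/C=C/C(=O)OCCOc1ccccc1`: > 5 h
- compound 2, `CCCN(C)C(=O)COC(=O)/C=C/c1ccc(NC(=O)C2(NC(=O)c3ccc4c(C5CCCC5)c(-c5ncc(Cl)cn5)n(C)c4c3)CCC2)cc1OCC`: 0.317 h

Of the compounds shown here, two have been tested in an ADME assay (liver) for pharmacokinetics, with Liver microsome (Homo sapiens) as the target, using microsomes; a lower number here means that the compound disappears faster, a higher number that the compound lasts longer. For compound 1 the result is a limit of the assay, > 5 h, and not a number (the limit of > 5 h in this assay, at which 1 of the 2 values shown sits). Among the measured compounds shown here, compound 2 is the only compound with an actual number, 0.317 h, so it stands alone as the single fixed point. For the measured compounds named here, the one measured step, an at least 15-fold lower number from compound 1 to compound 2 (1.19 log units; beyond the scatter), is large and beyond the scatter.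

Compound 3, `CCOc1cc(NC(=O)C2(NC(=O)c3ccc4c(C5CCCC5)c(-c5ncc(Cl)cn5)n(C)c4c3)CCC2)ccc1/C=C/C(=O)OCC(=O)N1CCCC1`, is not yet measured. It differs from compound 2 by pyrrolidin-1-yl in place of methyl(propyl)amino on a carbonyl carbon. The measured step changed a different part of that tail, so it bears on this change only loosely: it shows that the ester-linked group can matter a great deal, but here the carbamoyl is kept and only the two substituents on its nitrogen are tied into a ring. Compound 3 is therefore expected to stay close to compound 2 in this assay, with an expected step of a 1.1-fold higher number from compound 2 to compound 3 (0.04 log units; within the scatter), not beyond the scatter. The estimated half-life of compound 3 is 0.35 h, expected to fall between 0.15 h and 0.8 h.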

Compound 3, half-life: 1.65 h
Estimate against measurement, compound 3: 4.7-fold (0.67 log units) below; measured number above the stated range.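

In this assay, the amine on the carbonyl carbon matters on its own: tying methyl(propyl)amino into pyrrolidin-1-yl keeps the same 5 heavy atoms and the same carbamoyl link, yet gives a 5.2-fold higher number from compound 2 to compound 3 (0.72 log units; beyond the scatter), so a change far smaller than replacing the whole end of the tail can still move the half-life beyond the scatter. Even so, the tail ending in phenoxymethyl stays ahead of the one ending in (pyrrolidin-1-yl)carbonyl, with an at least 3.0-fold lower number from compound 1 to compound 3 (0.48 log units; beyond the scatter), and the true size of that step stays unknown. Compound 1 gives a limit of the assay and not a number: the limit of > 5 h in this assay, at which 1 of the 3 values shown sits.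

The compounds shown leave open whether the longer half-life goes with having a ring on the carbonyl carbon or with this particular ring, a question that piperidin-1-yl or morpholin-4-yl in the same place would help to answer. They also leave open why closing the ring changes the half-life, since nothing here shows what happens to any of these compounds in the microsomes.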